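The source may hold more compounds than are shown below. What is called first, only, known or untested is meant among the compounds shown, and "the series" means these compounds.

Compound 1 `CSc1nc(NCCCc2ccccc2)c2ccccc2n1` was examined in an ADME assay on 184B5 cells (Homo sapiens) for cytotoxicity, read by MTT assay, with a stated time of 72 h; on this read-out lower numbers stand for stronger inhibition of growth and higher numbers for weaker inhibition of growth. In this assay compound 1 gives > 100000 nM, which is a limit of the assay rather than a number. Compound 2 `CCCCC[Se]c1nc(NCc2ccccc2)c2ccccc2n1` also gives > 100000 nM in this assay, again a limit and not a measured number. Compound 3 `[SeH]c1nc([SeH])c2ccccc2n1` carries a different substitution on the shared core and gives 2500 nM in this assay. Among the three values shown, compound 1 therefore stands at the limit of > 100000 nM in this assay, at which 2 of the 3 values shown sit. Within the data shown here, no step between measured compounds that differ in a single place is available, so nothing measured can be set beside the change that follows.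

Compound 4 `CSc1nc(NCCCCc2ccccc2)c2ccccc2n1` has not yet been measured. Compared with compound 1 it carries benzyl in place of phenyl on a saturated chain carbon, three bonds along the chain from a nitrogen on an aromatic ring. The aromatic end of the side chain and the shared core are otherwise kept. Compound 1 offers only a limit in this assay, so no direction for the step can be read from it. The step expected here, a number no higher from compound 1 to compound 4 (the limit leaves the size open), is estimated to be none beyond the scatter, and the most probable outcome is that compound 4 again returns a limit. Compound 4 is expected to give about 100000 nM in this assay, with a range from 30000 nM to 300000 nM.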

Compound 4, concentration for total growth inhibition: 53600 nM
For compound 4 the middle estimate is 1.9-fold (0.27 log units) above the measured one; low and high end bracket the measured number.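

With benzyl in place of phenyl on a saturated chain carbon, three bonds along the chain from a nitrogen on an aromatic ring, this assay returns a measured number for compound 4, 53600 nM, where the phenyl compound offered none. Compound 1 remains a limit of the assay and not a number, as does one other compound shown: the limit of > 100000 nM in this assay, at which 2 of the 4 values shown sit. Among these compounds, the change therefore reads only as an at least 1.8-fold lower number from compound 1 to compound 4 (0.27 log units; that floor lies within the scatter), so this one-place change gives a first measured reading at this position, but its floor alone does not establish a change beyond the scatter, and its true size remains unknown.

From the compounds shown here alone, whether a longer chain than that of compound 4, or an amine or a carboxylic acid on the aromatic end of the side chain, would move the number in this assay stays open. Compound 2 and compound 3 each differ from compound 4 in more than one place, so neither can be compared with it, and the contribution of the rest of the molecule to the values shown remains unresolved.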